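Sulfonyl aryl exchange on a shared chromone-like scaffold

The source may report more compounds than this note shows. Statements on the series, on what has been measured and on what is new or still open speak of the compounds shown alone.

Measured compounds: compound 1 `C=CCNC(=O)n1c(-c2ccc(OC)cc2)cc(=O)c2c(OC)cc(OC)cc21`, 16000 nM; compound 2 `COc1ccc(-c2cc(=O)c3c(OC)cc(OC)cc3n2S(=O)(=O)c2ccc(C=O)cc2)cc1`, > 34400 nM.

In a functional assay on SUP-B15 cells (Homo sapiens) for antiproliferative activity, with a stated time of 72 h (a lower number here means that less compound is needed, a higher number that more compound is needed for the effect), compound 1 gives 16000 nM. For compound 2 only a limit is reported, > 34400 nM, which is the assay boundary rather than a number (the limit of > 34400 nM in this assay, at which 1 of the 2 values shown sits). The step of an at least 2.1-fold higher number from compound 1 to compound 2 (0.33 log units; beyond the scatter) concerns a different change and does not bear on the move to compound 3 `COc1ccc(-c2cc(=O)c3c(OC)cc(OC)cc3n2S(=O)(=O)c2cc(Cl)cc(Cl)c2O)cc1`, in which (3,5-dichloro-2-hydroxyphenyl in place of 4-formylphenyl on a sulfonyl sulfur). Among the compounds with values here, no measured step tests this replacement, so compound 3 is estimated at 35000 nM, within 8000 nM to 120000 nM, a step that the limit leaves unreadable from compound 2 to compound 3 expected to remain near the limit.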

Compound 3, half-maximal effective concentration: > 37900 nM
Compound 3: no number, only a limit; the forecaster's own chance of this, stated with the estimate: 65%; at least 1.0-fold (0.03 log units) between middle value and limit.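

Compound 2 and compound 3 each give only a limit in this assay, so the step between them cannot be read. Which of the two sulfonyl aryl groups, 4-formylphenyl or 3,5-dichloro-2-hydroxyphenyl, needs less compound remains open.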